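The source may hold more compounds than are shown below. What is called first, only, known or untested is meant among the compounds shown, and "the series" means these compounds.

Measured so far in a functional assay on RAW264.7 cells (Mus musculus) for inhibition, with stated times of 2 h and 24 h; on this read-out lower numbers stand for stronger inhibition and higher numbers for weaker inhibition:
- compound 1 `COc1ccc(/C=C2/c3cc(OC)cc(OC)c3[C@@H](c3ccc(OC)cc3)[C@@H]2c2cc(OC)cc(OC)c2)cc1`: 6260 nM
- compound 2 `COc1ccc([C@@H]2c3c(OC)cc(OC)cc3C(SCc3ccc(C)cc3)[C@H]2c2cc(OC)cc(OC)c2)cc1`: > 200000 nM (a limit of the assay, not a number)

Compound 2 stands at the limit of > 200000 nM in this assay, at which 1 of the 2 values shown sits. Going by the values given here, compound 1, at 6260 nM, holds the only actual number.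

Compound 3 `COc1ccc([C@@H]2c3c(OC)cc(OC)cc3C(C(O)c3ccc(C)cc3)[C@H]2c2cc(OC)cc(OC)c2)cc1` carries hydroxy(4-methylphenyl)methyl in place of the (4-methylbenzyl)sulfanyl of compound 2, on a saturated ring carbon next to the ring atom that bears a 3,5-dimethoxyphenyl group: hydroxy(4-methylphenyl)methyl in place of (4-methylbenzyl)sulfanyl on a saturated ring carbon.

No measured step sizes this swap, so the expectation is loose. Inhibition somewhat stronger than the limit of compound 2 is expected, and another reading at a limit remains possible. For compound 3, inhibition probably still weaker than for compound 1 at 6260 nM is expected. The expected change is an at least 3.3-fold lower number from compound 2 to compound 3 (0.52 log units; beyond the scatter), an estimate only. For compound 3 the estimated value is 60000 nM, with an expected range of 10000 nM to 250000 nM.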

Compound 3, half-maximal inhibitory concentration: 26500 nM
The estimate for compound 3 lay 2.3-fold (0.35 log units) above the measured number; low and high end bracket the measured number.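

In this assay, the saturated ring carbon next to the ring atom that bears a 3,5-dimethoxyphenyl group responds to the identity of its substituent: hydroxy(4-methylphenyl)methyl in place of (4-methylbenzyl)sulfanyl gives an at least 7.5-fold lower number from compound 2 to compound 3 (0.87 log units; beyond the scatter). With the heavy-atom count of the group and its aromatic ring unchanged, compound 3 at 26500 nM shows that a substituent of this size at this carbon is compatible with a measurable value. The true size of the step stays unknown, since compound 2 gives only a limit of the assay and not a number: the limit of > 200000 nM in this assay, at which 1 of the 3 values shown sits.

The step does not separate the loss of the sulfur from the gain of the hydroxy group. A plain 4-methylbenzyl group or an amine linking the same aryl ring at this carbon would tell these two apart.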